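The compounds below may be only part of what the source reports. "The series", "measured", "known", "first", "only" and "open" are said of these compounds alone.

Of the compounds shown here, three built on one shared core have been tested in a functional assay (trachea) with Rattus norvegicus as the target; on this read-out higher numbers stand for higher potency (the scale is a negative logarithm) and lower numbers for lower potency. Compound 1 `CC(=O)c1ccc2c(c1)C(n1ccccc1=O)=CC(C)(C)O2` gives 6.65. Compound 2 `CCC(=O)c1ccc2c(c1)C(n1ccccc1=O)=CC(C)(C)O2` gives 5.85, and compound 3 `COc1ccc(C(=O)c2ccc3c(c2)C(n2ccccc2=O)=CC(C)(C)O3)cc1` gives 5.72. Compound 3 therefore holds the lowest of the three numbers: its nearest neighbour is compound 2, with the step of a number 0.13 log units lower from compound 2 to compound 3 (within the scatter) within the scatter, while the step of a number 0.93 log units lower from compound 1 to compound 3 (beyond the scatter) lies beyond it.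

Compound 4 `CC1(C)C=C(n2ccccc2=O)c2cc(C(=O)c3ccco3)ccc2O1` has not yet been measured. It differs from compound 3 by furan-2-yl in place of 4-methoxyphenyl on a carbonyl carbon. The measured steps that touch this same carbonyl carbon are a number 0.93 log units lower from compound 1 to compound 3 (beyond the scatter) and a number 0.13 log units lower from compound 2 to compound 3 (within the scatter), where a methyl or an ethyl gave way to the 4-methoxyphenyl. Both of those earlier groups gave numbers no lower than compound 3, and nothing yet shows how a five-membered aromatic ring with one hetero atom behaves at this carbonyl carbon. The step of a number 0.18 log units higher from compound 3 to compound 4 (within the scatter) is therefore expected to stay within the scatter. Compound 4 is estimated at 5.9 in this assay, with a range from 5.3 to 6.5.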

Compound 4, logarithm of the reciprocal of the active concentration, log(1/C): 5.92
Compound 4: the middle estimate sits 0.02 log units below what was measured, and the stated range covers the measured number.
By their numbers in this assay, from the lowest: compounds 3, 2 and 4 (each within the scatter of the next); then compound 1.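

Placing furan-2-yl on this carbonyl carbon gives a step of a number 0.20 log units higher from compound 3 to compound 4 (within the scatter) against the 4-methoxyphenyl, so a five-membered aromatic ring with one hetero atom and a larger six-membered one cannot be told apart here. The comparison with an open chain gives a number 0.07 log units higher from compound 2 to compound 4 (within the scatter) and likewise separates furan-2-yl from ethyl by nothing beyond the usual spread of repeat measurements. Only the methyl of compound 1 stands apart, as the step of a number 0.73 log units lower from compound 1 to compound 4 (beyond the scatter) shows, so now three different groups, two of them rings, share one level below it.

On these data alone, whether an amine, a carboxylic acid or a longer chain at this carbonyl carbon would reach the level of compound 1 remains open. Nothing available explains why the methyl stands apart.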